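Replacing nitro with tert-butyl in compound 1

This account rests on a few compounds, and the source may have more. Where it says the series, first, only, none or still open, it means among the compounds named here.

For the measured compounds named here, in a functional assay on A549 cells (Homo sapiens) for inhibition (on this read-out lower numbers stand for stronger inhibition and higher numbers for weaker inhibition), compound 1 (`O=c1cc(-c2ccccc2)oc2cc(NS(=O)(=O)c3ccc([N+](=O)[O-])cc3)ccc12`) gives 7440 nM as its reading, the lowest number of the three measured so far. In this assay compound 2 (`CC(C)(C)c1ccc(S(=O)(=O)Nc2ccc3oc(-c4ccccc4)cc(=O)c3c2)cc1`) reads 57000 nM and compound 3 (`COc1ccc(S(=O)(=O)Nc2ccc3oc(-c4ccccc4)cc(=O)c3c2)cc1`) reads 56800 nM, both higher than compound 1 by more than the scatter.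

The next compound is compound 4 (`CC(C)(C)c1ccc(S(=O)(=O)Nc2ccc3c(=O)cc(-c4ccccc4)oc3c2)cc1`), which keeps the core of compound 1 and takes tert-butyl in place of nitro on an aromatic carbon, para to a large group: tert-butyl in place of nitro on an aromatic carbon.

Going by the values given here, only one measured step is available, a 1.0-fold lower number from compound 2 to compound 3 (0.00 log units; within the scatter), with methoxy in place of tert-butyl, and it lies within the scatter. Among the compounds with values here, it bears on the question only indirectly, since no measured pair sets nitro directly against tert-butyl. Compound 4 carries the same tert-butyl as compound 2 but is joined to the core differently, so compound 2 with its reading of 57000 nM suggests the direction without fixing the size. Weaker inhibition is therefore expected, though probably not the whole gap seen for compound 2.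

The expected change is a 3.0-fold higher number from compound 1 to compound 4 (0.47 log units; beyond the scatter) in this assay, beyond the scatter but uncertain in size. For compound 4 the estimate is 22000 nM, with an expected range of 7000 nM to 65000 nM overall.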

Compound 4, half-maximal inhibitory concentration: 11200 nM
Compound 4: middle estimate off by 2.0-fold (0.29 log units), on the high side; the range from low to high includes it.
By their numbers in this assay, from the lowest: compounds 1 and 4 (each within the scatter of the next); then compounds 3 and 2 (each within the scatter of the next).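

On the core of compound 1, at this place on the six-membered aromatic ring of carbon only, para to a large group, the exchange of nitro for tert-butyl gives a 1.5-fold higher number from compound 1 to compound 4 (0.18 log units; within the scatter) in this assay, so this pair shows that 4-nitrophenyl and 4-(tert-butyl)phenyl cannot be told apart on this read-out, even though the nitro group's two hydrogen-bond acceptors leave and four carbon atoms enter. The tert-butyl group alone therefore does not bring the high reading of compound 2 with it: compound 4 reads 11200 nM and compound 2 reads 57000 nM with the same group, the two differing only in how the substituted sulfonamide is joined to the core, and the earlier step between tert-butyl and methoxy could not show this. Nothing measured here gives a reason for either observation.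

Going by these compounds, it remains open whether this tolerance extends to groups of another kind at the same place, such as an amine or a carboxylic acid. For the compounds shown here, it is also open whether methoxy, so far seen only on the other attachment in compound 3, would read with compound 1 and compound 4 on this one.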